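The compounds below may be only part of what the source reports. "The series", "measured", "known", "first", "only" and "open" are said of these compounds alone.

Measured so far, in a functional assay on the whole organism (Tail, strain ICR) with Mus musculus as the target, in the tail flick test, with a stated time of 30 min, at a dose of 25 umol/kg by the oral route; a lower number here means a weaker effect, a higher number a stronger effect of the compound at the dose given:

Compound 1, `N=C(N)NCCC[C@H](NC(=O)CN(c1nc(Cl)nc2[nH]cnc12)C1CC1)C(=O)O`, gives 45.4% in this assay.
Compound 2, `O=C(CN(c1ncnc2c1ncn2C1CCCCO1)C1CC1)N[C@@H](CCC(=O)OCc1ccccc1)C(=O)OCc1ccccc1`, gives 32.6% in this assay.
Compound 3, `CC[C@H](C)[C@H](NC(=O)CN(c1nc(Cl)nc2[nH]cnc12)C1CC1)C(=O)O`, gives 30.3% in this assay.

Compound 3 holds the lowest of the three numbers, though compound 2 sits within the scatter of it, so no order between those two can be read; only compound 1 stands clearly higher, by a number 15.1 percentage points lower from compound 1 to compound 3 (beyond the scatter).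

The next compound, compound 4, `O=C(O)CNC(=O)CN(c1nc(Cl)nc2[nH]cnc12)C1CC1`, has not yet been measured in this assay. It differs from compound 3 in one place: hydrogen in place of sec-butyl on a saturated chain carbon bound to an amide-type nitrogen and a carbonyl carbon. Going by the values given here, the only measured step that touches the same place is the one from compound 1 to compound 3, where a group of 4 heavy atoms replaced a group of 7 heavy atoms and the read-out fell by a number 15.1 percentage points lower from compound 1 to compound 3 (beyond the scatter), a modest step beyond the scatter. The change to compound 4 goes further in the same sense, stripping the sec-butyl away to a bare hydrogen, so a further step downward in this assay, or at most one within the scatter, is expected rather than a rise. Among the compounds with values here, no measured pair shows the exact sec-butyl-to-hydrogen change, so the size is uncertain. Compound 4 is therefore estimated at 23%, within 10% to 38%, an expected step of a number 7.3 percentage points lower from compound 3 to compound 4 (within the scatter).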

Compound 4, a percentage reported as activity, at one dose (the size of the read-out at that dose, not a potency): 32.2%
Compound 4: middle estimate off by 9.2 percentage points, on the low side, within the range that was stated.
By their numbers in this assay, from the lowest: compounds 3, 4 and 2 (each within the scatter of the next); then compound 1.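

In this assay, cutting the side group on this saturated chain carbon, bound to an amide-type nitrogen and a carbonyl carbon, from sec-butyl down to a bare hydrogen gives a number 1.9 percentage points higher from compound 3 to compound 4 (within the scatter), so at this dose the read-out does not separate the two. The earlier fall from compound 1 therefore does not grow as the group shrinks further: the new comparison gives a number 13.2 percentage points lower from compound 1 to compound 4 (beyond the scatter), and compound 3 and compound 4 both stand clearly apart from compound 1, which suggests that among these three only the group of 7 heavy atoms in compound 1 makes a visible difference. No measurement here explains why the position behaves this way.

Three groups cannot show whether the higher number belongs to something specific in that larger group or to its size alone; a chain ending in a simple amine, or one ending in a carboxylic acid, on the same carbon would help to separate these possibilities. A plain longer hydrocarbon chain there would also show whether chain length by itself can reach the level of compound 1.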